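The compounds below may be only part of what the source reports. "The series", "measured", "known", "first", "only" and "open" are said of these compounds alone.

Measured so far in an ADME assay on MT4 cells (Homo sapiens) for cytotoxicity, read by spectrophotometry, with a stated time of 5 days; on this read-out higher numbers stand for lower toxicity in this test and lower numbers for higher toxicity in this test:
Compound 1 `Cc1ccc2c(c1)/C(=N/NC(=S)NO)C(=O)N2CN(C)C`: 651000 nM
Compound 2 `CN(C)CN1C(=O)/C(=N\NC(=S)NO)c2cc(F)ccc21`: 599000 nM
Compound 3 `CCn1cc(C(=O)O)c(=O)c2cc(F)c(N3CCN(CN4C(=O)/C(=N\NC(=S)NO)c5cc(C)ccc54)CC3)cc21`: 327000 nM

Compound 1 and compound 2 share a core and differ by fluoro in place of methyl on an aromatic carbon; this gave a 1.1-fold lower number from compound 1 to compound 2 (0.04 log units; within the scatter). Compound 3 stands with a larger core; the difference between the cores of compound 3 and compound 1 is not broken down here, and the values of compound 3 and compound 2 lie within the scatter of each other.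

Compound 4 `CCn1cc(C(=O)O)c(=O)c2cc(F)c(N3CCN(CN4C(=O)/C(=N\NC(=S)NO)c5cc(F)ccc54)CC3)cc21` is not yet measured. It differs from compound 3 by fluoro in place of methyl on an aromatic carbon, the same change as that from compound 1 to compound 2. From that earlier step, a step of about a 1.1-fold lower number from compound 3 to compound 4 (0.04 log units; within the scatter) is expected for compound 4 in this assay. Compound 4 is accordingly estimated at 300000 nM, between 150000 nM and 600000 nM.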

Compound 4, half-maximal cytotoxic concentration: 208000 nM
Compound 4: middle estimate off by 1.4-fold (0.16 log units), on the high side; the measured number falls inside the stated range.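

In this assay, fluoro in place of methyl on an aromatic carbon gives a 1.6-fold lower number from compound 3 to compound 4 (0.20 log units; within the scatter). Set beside the earlier step on the smaller core, the result does not separate the two cores: the same change on two cores in this assay, a 1.1-fold lower number (0.04 log units; within the scatter) from compound 1 to compound 2 and a 1.6-fold lower number (0.20 log units; within the scatter) from compound 3 to compound 4, 1.4-fold (0.16 log units) apart, within the scatter of two such steps. The change therefore carries across these two cores only in the sense that it stays within the scatter on both; this does not show a real effect of the change on either core, nor that a step of real size would carry over in the same way.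

Open, on these data alone, is whether another group on that aromatic carbon, such as chloro, methoxy or nitro, gives a step beyond the scatter on either core. Also open, as far as these compounds go, is whether fluoro in place of methyl behaves alike on a third core.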